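The compounds below may be only part of what the source reports. "The series", "measured", "known", "first", "only" and "open" are said of these compounds alone.

Measured so far:
compound 1 `Cc1cc(C2CCC2)c(S(C)(=O)=O)cc1C(=O)N=C(N)N` — 8.2 nM
compound 2 `Cc1c(C(=O)N=C(N)N)cc(S(C)(=O)=O)c(C)c1C` — 55 nM

Both numbers come from a functional assay for inhibition of sodium/hydrogen exchanger (Oryctolagus cuniculus); on this read-out lower numbers stand for stronger inhibition and higher numbers for weaker inhibition. Going by the values given here, compound 1 stands at the lower of the two; compound 2, with 55 nM, lies higher by a margin beyond the usual scatter, but the two structures differ in several places and no single step can be drawn between them. Compound 3 `Cc1cc(Sc2ccc(Cl)cc2)c(S(C)(=O)=O)cc1C(=O)N=C(N)N` is not yet measured. It differs from compound 1 in one place: (4-chlorophenyl)sulfanyl in place of cyclobutyl on an aromatic carbon. Among the compounds with values here, no measured step covers a change of this kind, so its size is open. A small weakening, about the size of the scatter, is expected: a 1.8-fold higher number from compound 1 to compound 3 (0.26 log units; within the scatter). For compound 3 the estimate in this assay is 15 nM, with a range from 4 nM to 60 nM.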

Compound 3, half-maximal inhibitory concentration: 19 nM
Beside the measured number, compound 3's estimate is 1.3-fold (0.10 log units) below it, within the range that was stated.
By their numbers in this assay, from the lowest: compound 1; then compound 3; then compound 2.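

In this assay, (4-chlorophenyl)sulfanyl in place of cyclobutyl on the aromatic carbon ortho to the methylsulfonyl group gives a 2.3-fold higher number from compound 1 to compound 3 (0.36 log units; beyond the scatter), a modest change. This position therefore accepts a larger group carrying an aromatic ring, with compound 3 still at 19 nM. Nothing available accounts for the step. The compounds shown do not separate the contribution of the sulfur link from that of the 4-chlorophenyl ring. From the compounds shown here alone, how a plain phenyl, a phenoxy group or an amine would read at this carbon remains open.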